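The source may report more compounds than this note shows. Statements on the series, on what has been measured and on what is new or still open speak of the compounds shown alone.

Values measured in a functional assay on ECa-109 cells for inhibition, with ECa-109 cell line (Homo sapiens) as the target, read by sulforhodamine B assay (on this read-out lower numbers stand for stronger inhibition and higher numbers for weaker inhibition), are:
- Compound 1 `O=C1C(Nc2ccc(I)cc2)=CC(=O)c2c1nc1n2[C@H]2OC[C@@H](O)[C@H]2OC1` gives 2530 nM
- Compound 2 `O=C1C(Nc2ccccc2)=CC(=O)c2c1nc1n2[C@H]2OC[C@@H](O)[C@H]2OC1` gives 3560 nM
- Compound 3 `Cc1ccc(NC2=CC(=O)c3c(nc4n3[C@H]3OC[C@@H](O)[C@H]3OC4)C2=O)cc1` gives > 4000 nM

Compound 3 has no exact number, only a limit of the assay (the limit of > 4000 nM in this assay, at which 1 of the 3 values shown sits). Compound 4 `Cc1ccc(NC2=CC(=O)c3c(nc4n3[C@H]3OC[C@@H](O)[C@H]3OC4)C2=O)cc1C` differs from compound 3 by methyl in place of hydrogen on an aromatic carbon, ortho to a methyl group (methyl in place of hydrogen on an aromatic carbon), turning 4-methylphenyl into 3,4-dimethylphenyl. Among the measured compounds shown here, the closest precedent is the same kind of swap (an at least 1.1-fold higher number from compound 2 to compound 3 (0.05 log units; that floor lies within the scatter)), and the iodo changes are also small (a 1.4-fold higher number from compound 1 to compound 2 (0.15 log units; within the scatter); an at least 1.5-fold higher number from compound 1 to compound 3 (0.19 log units; that floor lies within the scatter)). As far as these compounds go, no step beyond the scatter is therefore expected, though the true size of the steps to compound 3 stays unknown. The expected change is small (a number no higher from compound 3 to compound 4 (the limit leaves the size open)). For compound 4 the estimate is 4000 nM (expected range 2200 nM to 7000 nM), and another limit would be no surprise.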

Compound 4, half-maximal inhibitory concentration: 4090 nM
Estimate against measurement, compound 4: 1.0-fold (0.01 log units) below, and the stated range covers the measured number.
By their numbers in this assay, from the lowest: compounds 1, 2 and 4 (each within the scatter of the next).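

In this assay, 3,4-dimethylphenyl in place of phenyl on the amine nitrogen gives a 1.1-fold higher number from compound 2 to compound 4 (0.06 log units; within the scatter), and in place of 4-iodophenyl it gives a 1.6-fold higher number from compound 1 to compound 4 (0.21 log units; within the scatter). Plain phenyl, 4-iodophenyl and 3,4-dimethylphenyl therefore give numbers that cannot be told apart, so a second methyl group on this ring opens no real gap to either of the other two. The step from compound 3 to compound 4 cannot be read: the limit of > 4000 nM in this assay, at which 1 of the 4 values shown sits.

As far as these compounds go, whether an amine, a carboxylic acid or a longer chain on this ring would move the number beyond the scatter remains open.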